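The source may report more compounds than this note shows. Statements on the series, on what has been measured and on what is new or still open speak of the compounds shown alone.

Among the compounds with values here, compound 1 `COc1cc2c(Oc3ccc(NC(=O)c4cc(-c5ccc(F)cc5)on4)cc3)ccnc2cc1OCCCN1CCC(C)CC1` is one of three compounds measured in a functional assay on PC-3 cells (Homo sapiens) for antiproliferative activity, read by MTT assay, with a stated time of 72 h; on this read-out lower numbers stand for stronger inhibition and higher numbers for weaker inhibition; compound 1 gives 2040 nM. Compound 3 `COc1cc2c(Oc3ccc(NC(=O)C4(c5nnc(-c6ccc(F)cc6)o5)CC4)cc3F)ccnc2cc1OCCCN1CCN(C)CC1` gives 1670 nM, a number within the scatter of compound 1, so the two cannot be told apart. Compound 2 `COc1cc2nccc(Oc3ccc(NC(=O)c4ncc(-c5ccc(F)cc5)o4)cc3)c2cc1OC` gives 21900 nM, a higher number beyond the scatter, so compound 1 is the stronger of that pair. Compound 4 `COc1cc2c(Oc3ccc(NC(=O)c4nnc(-c5ccc(F)cc5)o4)cc3)ccnc2cc1OCCCN1CCC(C)CC1` is not yet measured. It differs from compound 1 in one place: 5-(4-fluorophenyl)-1,3,4-oxadiazol-2-yl in place of 5-(4-fluorophenyl)-1,2-oxazol-3-yl on a carbonyl carbon. Within the data shown here, no measured pair shows this exact change, but compound 3, which also carries a 5-(4-fluorophenyl)-1,3,4-oxadiazol-2-yl group, sits close to compound 1. The step from compound 1 to compound 4 is expected to be small, a 1.2-fold higher number from compound 1 to compound 4 (0.09 log units; within the scatter), within the scatter. Compound 4 is therefore estimated at 2500 nM, between 800 nM and 8000 nM.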

Compound 4, half-maximal inhibitory concentration: 3810 nM
Compound 4: middle estimate off by 1.5-fold (0.18 log units), on the low side; the range from low to high includes it.
By their numbers in this assay, from the lowest: compounds 3, 1 and 4 (each within the scatter of the next, the first and the last beyond it); then compound 2.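

Within the data shown here, this is the first direct reading of a change at this place on the carbonyl carbon: in this assay, putting 5-(4-fluorophenyl)-1,3,4-oxadiazol-2-yl in place of 5-(4-fluorophenyl)-1,2-oxazol-3-yl gives a 1.9-fold higher number from compound 1 to compound 4 (0.27 log units; within the scatter), so the two compounds cannot be told apart. Exchanging one of these five-membered rings for the other, with the same count of heavy atoms, thus has no effect that this assay can resolve. Nothing measured here bears on the reason for this result. Still open, as far as these compounds go, is what happens when another group, such as a carboxylic acid or a morpholine ring, replaces the 4-fluorophenyl on the new ring.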